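Swapping a Bromophenyl for a Methylbenzyl on Sulfur

The compounds below may be only part of what the source reports. "The series", "measured", "known", "first", "only" and "open" are said of these compounds alone.

Of the compounds shown here, three have been measured in a functional assay on DU-145 cells (Homo sapiens) for inhibition, read by trypan blue exclusion, with a stated time of 96 h; a higher number here means a weaker inhibitor of growth, a lower number a stronger inhibitor of growth. Compound 3 `O=C(/C(=C\c1c(O)cc(O)cc1O)Sc1ccc(Br)cc1)c1ccc(Cl)cc1` gives 50000 nM, and compound 1 `Cc1ccc(CS/C(=C/c2c(O)cc(O)cc2O)C(=O)c2ccc(Cl)cc2)cc1`, which differs from it only as 4-methylbenzyl in place of 4-bromophenyl on a sulfur, gives 50000 nM; the step of no change at the digits printed from compound 3 to compound 1 (within the scatter) is a flat one. Compound 2 `COc1ccccc1/C=C(\C(=O)c1ccc(Cl)cc1)S(=O)(=O)c1ccc(Br)cc1` is built on a different core; the difference between the two cores is not broken down here. In this assay compound 2 gives 10000 nM, the lowest of the three numbers, and its distance to each of the other two lies beyond the usual scatter.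

Compound 4 `COc1ccccc1/C=C(\C(=O)c1ccc(Cl)cc1)S(=O)(=O)Cc1ccc(C)cc1` has not yet been measured. It differs from compound 2 as 4-methylbenzyl in place of 4-bromophenyl on a sulfonyl sulfur. This is the same kind of change as that from compound 3 to compound 1, but the place is not identical: there the group sat on a sulfur whose other neighbour was the double-bonded chain carbon, here it sits on a sulfonyl sulfur whose other neighbours are the double-bonded chain carbon. Because the step of no change at the digits printed from compound 3 to compound 1 (within the scatter) was flat, a similarly small step is expected here, a 1.2-fold higher number from compound 2 to compound 4 (0.08 log units; within the scatter). Compound 4 is therefore estimated at 12000 nM, with a likely range from 4000 nM to 40000 nM. The range is kept wide: the change has been seen only once, and on a different core.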

Compound 4, concentration for 50% growth inhibition: 10000 nM
Beside the measured number, compound 4's estimate is 1.2-fold (0.08 log units) above it; the range from low to high includes it.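

In this assay, placing 4-methylbenzyl in place of 4-bromophenyl on a sulfonyl sulfur gives no change at the digits printed from compound 2 to compound 4 (within the scatter). Set beside the same swap on the other core, the two steps agree: the same change on two cores in this assay, no change at the digits printed (within the scatter) from compound 3 to compound 1 and no change at the digits printed (within the scatter) from compound 2 to compound 4, 1.0-fold (0.00 log units) apart, within the scatter of two such steps Within this small set, the swap therefore carries from one core to the other, with the number staying flat both times, but this rests on only two pairs of compounds and does not show that it would stay flat on any further core.

The compounds shown leave open what other groups on the sulfur would do, for example a longer alkyl chain, an amine or a carboxylic acid in place of the 4-methylbenzyl. They also leave open whether the agreement between the two steps would hold in a different read-out, since everything here comes from a single growth measurement on one cell line.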